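The compounds below may be only part of what the source reports. "The series", "measured", "known", "first", "only" and "open" are said of these compounds alone.

In an ADME assay on Vero cells (Chlorocebus sabaeus) for cytotoxicity, read by WST assay (on this read-out lower numbers stand for higher toxicity in this test and higher numbers for lower toxicity in this test), compound 1 `O=c1[nH]c(Nc2cc(F)cc(F)c2)nc2cc([N+](=O)[O-])ccc12` gives > 25000 nM, a limit of the assay rather than a number. Compound 2 `Nc1ccc2c(=O)[nH]c(Nc3cc(F)cc(F)c3)nc2c1` is reached from compound 1 through (amino in place of nitro on an aromatic carbon). In this assay compound 2 gives > 25000 nM, which is again a limit. The two limits leave a step that the two limits leave unreadable from compound 1 to compound 2 without a readable size. Compound 3 `O=c1[nH]c(Nc2cc(Cl)cc(Cl)c2)nc2cc([N+](=O)[O-])ccc12` gives > 25000 nM in this assay, also a limit; how its core differs from the core of compound 1 is not broken down here. Compound 4 `Nc1ccc2c(=O)[nH]c(Nc3cc(Cl)cc(Cl)c3)nc2c1` has not yet been measured and differs from compound 3 by amino in place of nitro on an aromatic carbon, the same change that leads from compound 1 to compound 2. Because (the limit of > 25000 nM in this assay, at which 3 of the 3 values shown sit), compound 4 is expected to remain at that limit as well, so the expected step that the limit leaves unreadable from compound 3 to compound 4 is small. The estimate for compound 4 is therefore 30000 nM.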

Compound 4, half-maximal cytotoxic concentration: > 25000 nM
Compound 4 gave a limit, no number; the forecaster's own chance of this, stated with the estimate: 85%; the middle value does not contradict the limit.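

In this assay, among the compounds shown here, compound 3 and compound 4 both give only a limit, and no step between them can be read. The compounds shown leave open what actual number any of them would give, and whether amino in place of nitro shifts the read-out at all: the limit of > 25000 nM in this assay, at which 4 of the 4 values shown sit.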